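Swapping iodo for chloro on two different cores

The compounds below may be only part of what the source reports. "The series", "measured", "known", "first", "only" and "open" are said of these compounds alone.

Measured so far:
compound 1, `O=C(O)/C(S)=C/c1c[nH]c2cc(Cl)ccc12` — 100 nM
compound 2, `O=C(O)/C(S)=C/c1c[nH]c2cc(I)ccc12` — 300 nM
compound 3, `O=C(O)/C(S)=C/c1cccc(I)c1` — 23900 nM

These three compounds were tested in an assay on isolated protein for inhibition of Calpain-1 catalytic subunit (Sus scrofa); on this read-out lower numbers stand for stronger inhibition and higher numbers for weaker inhibition. Compound 1 and compound 2 share a core and differ in one place, (chloro in place of iodo on an aromatic carbon), which gave a 3.0-fold lower number from compound 2 to compound 1 (0.48 log units; beyond the scatter). Compound 3 has a different core; how the two cores differ is not broken down here, but compound 3 gives the highest number of the three.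

Compound 4, `O=C(O)/C(S)=C/c1cccc(Cl)c1`, is not yet measured. It differs from compound 3 by chloro in place of iodo on an aromatic carbon. The surroundings of the place are not the same as before: in compound 2 the aromatic carbon is part of a fused or bridged system of two rings, meta to a fused ring and para to a fused ring, while in compound 3 it is on a six-membered aromatic ring of carbon only, meta to a group of 6 heavy atoms. So this is the same kind of change, not the same change. Because a 3.0-fold lower number from compound 2 to compound 1 (0.48 log units; beyond the scatter) was modest, a step of similar size is expected for compound 4, namely a 3.0-fold lower number from compound 3 to compound 4 (0.48 log units; beyond the scatter), with wide uncertainty since the core differs. The estimate for compound 4 in this assay is 8000 nM, between 2500 nM and 25000 nM.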

Compound 4, half-maximal inhibitory concentration: 13100 nM
The estimate for compound 4 lay 1.6-fold (0.21 log units) below the measured number; the measured number falls inside the stated range.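

In this assay, the step for chloro in place of iodo on the core of compound 3 reads a 1.8-fold lower number from compound 3 to compound 4 (0.26 log units; within the scatter), so on this core the swap cannot be told apart from the scatter of repeated measurements. Set beside the earlier step, the swap gives results on the two cores that cannot be told apart: the same change on two cores in this assay, a 3.0-fold lower number (0.48 log units; beyond the scatter) from compound 2 to compound 1 and a 1.8-fold lower number (0.26 log units; within the scatter) from compound 3 to compound 4, 1.6-fold (0.22 log units) apart, within the scatter of two such steps. Among the compounds shown here, this does not prove that the step is identical on both cores, since each core offers only one pair and the step on the core of compound 3 is too small to read on its own.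

The compounds shown leave open how other groups on the same aromatic carbon, such as fluoro, methyl or an amine, would compare with chloro and iodo. On these data alone, whether such groups would also behave alike on both cores remains open too.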